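A bromo compound at the edge of measurement

The compounds below may be only part of what the source reports. "The series", "measured", "known", "first", "only" and "open" are said of these compounds alone.

Going by the values given here, compound 2 `O=c1c([C@@H]2C[C@H](c3ccccc3)ON2c2ccccc2)coc2ccc(Br)cc12` holds the only true number in this small set: in a functional assay on THP-1 cells (Homo sapiens) for inhibition, read by sulforhodamine B assay, with a stated time of 48 h (on this read-out higher numbers stand for weaker inhibition and lower numbers for stronger inhibition), compound 2 gives 60000 nM. Compound 3 `Cc1ccc2occ([C@@H]3C[C@H](c4ccccc4)ON3c3ccccc3)c(=O)c2c1` gives > 60000 nM, which is a limit of the assay and not a number. Among the compounds with values here, the one measured step, methyl in place of bromo on an aromatic carbon, is a number no lower from compound 2 to compound 3 (the limit leaves the size open). Going by these compounds, its size stays open because of the limit of > 60000 nM in this assay, at which 2 of the 3 values shown sit.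

Compound 4 `CCO[C@H]1C[C@@H](c2coc3ccc(Br)cc3c2=O)N(c2ccccc2)O1` keeps the bromo of compound 2 but changes another place: ethoxy in place of phenyl on a saturated ring carbon. The bromo to methyl step therefore says little about this change. Ethoxy already stands in compound 1 `CCO[C@H]1C[C@@H](c2coc3ccccc3c2=O)N(c2ccccc2)O1`, and compound 1 gives > 60000 nM, again only a limit. With that value as the closest guide, no gain in inhibition is expected, and the expected change is no more than the usual scatter: no change at the digits printed from compound 2 to compound 4 (within the scatter). The estimate for compound 4 is 60000 nM, within an expected range of 30000 nM to 120000 nM.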

Compound 4, half-maximal inhibitory concentration: > 60000 nM
Compound 4: only a limit was reported; the forecaster's own chance of this, stated with the estimate: 65%; the middle value sits exactly at the limit.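

In this assay compound 4 gives > 60000 nM as a limit of the assay and not a number. With the bromo kept, the change on the saturated ring carbon next to the ring oxygen is a number no lower from compound 2 to compound 4 (the limit leaves the size open) and shows that ethoxy there yields no readable number, whether the bromo is present, as in compound 4, or hydrogen stands in its place, as in compound 1. Neither the size of that step nor the effect of bromo in place of hydrogen can be read, because so many values sit at the same limit: the limit of > 60000 nM in this assay, at which 3 of the 4 values shown sit.

Going by these compounds, whether an amine or a longer chain on this saturated ring carbon would bring a readable number stays open. Also open, on these data alone, is how far, if at all, the compounds at the limit lie from compound 2.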